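The compounds below may be only part of what the source reports. "The series", "measured", "known", "first", "only" and "open" are said of these compounds alone.

In a functional assay on CWR22R cells (Homo sapiens) for antiproliferative activity, read by propidium iodide staining, with a stated time of 96 h (a higher number here means a weaker inhibitor, a lower number a stronger inhibitor), compound 1 `CC(O)(CSc1ccc(C(F)(F)F)cc1)C(=O)Nc1ccc(S(F)(F)(F)(F)F)cc1` gives 14800 nM, and compound 2 `CC(O)(CSc1ccc(OC(F)(F)F)cc1)C(=O)Nc1ccc(S(F)(F)(F)(F)F)cc1` gives 14900 nM. Among the measured compounds shown here, these are the only two numbers so far, and they lie within the scatter of each other, so compound 1 holds no separate rank. Compound 3 `CC(O)(CSc1ccc(C(F)(F)F)cn1)C(=O)Nc1ccc(S(F)(F)(F)(F)F)cc1` differs from compound 1 by 5-(trifluoromethyl)pyridin-2-yl in place of 4-(trifluoromethyl)phenyl on a sulfur. For the measured compounds named here, only one measured step bears on this change, and only loosely: a 1.0-fold higher number from compound 1 to compound 2 (0.00 log units; within the scatter), with trifluoromethoxy in place of trifluoromethyl on an aromatic carbon. Going by the values given here, that step leaves the six-membered aromatic ring of carbon only in place, so no measurement yet tests a ring with a hetero atom. No shift beyond the scatter is therefore expected, though with little support. The expected change is a 1.0-fold higher number from compound 1 to compound 3 (0.01 log units; within the scatter). For compound 3 the estimated value is 15000 nM, with an expected range from 7000 nM to 32000 nM.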

Compound 3, half-maximal inhibitory concentration: 20000 nM
For compound 3 the middle estimate is 1.3-fold (0.12 log units) below the measured one; low and high end bracket the measured number.
By their numbers in this assay, from the lowest: compounds 1, 2 and 3 (each within the scatter of the next).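

In this assay, among the compounds shown here, the change on the sulfur from 4-(trifluoromethyl)phenyl to 5-(trifluoromethyl)pyridin-2-yl gives a 1.4-fold higher number from compound 1 to compound 3 (0.13 log units; within the scatter) and is the first step here to put a hetero atom into the aromatic ring. The entering group adds a hydrogen-bond acceptor at the same heavy-atom count, and in this pair that exchange stays within the scatter, so this position accepts a ring nitrogen without a readable change in antiproliferative activity. Nothing available bears on why the number behaves this way.

From the compounds shown here alone, whether a pyrimidin-2-yl ring, or a nitrile in place of the trifluoromethyl on the pyridine ring, would move the number beyond the scatter remains open. Going by these compounds, the rest of the core of compound 1 stays the same in all three compounds, so it is also open whether the ring nitrogen would behave alike with a sulfone in place of the sulfur.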